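Replacing the carbamate of compound 3 with a cyclopentylmethyl amine

The source may report more compounds than this note shows. Statements on the series, on what has been measured and on what is new or still open speak of the compounds shown alone.

Compound 1 `CC(C)(C)OC(=O)N1CCC(O[C@H]2CC[C@H](Oc3ccc(S(C)(=O)=O)cn3)CC2)CC1`: 110 nM
Compound 2 `CC(C)OC(=O)N1CCC(O[C@H]2CC[C@H](Oc3ccc(S(C)(=O)=O)nc3)CC2)CC1`: 201 nM
Compound 3 `CC(C)OC(=O)N1CCC(O[C@H]2CC[C@H](Oc3cnc(S(C)(=O)=O)cn3)CC2)CC1`: 119 nM

All three compounds were tested in a functional assay on isolated protein for agonist activity at Glucose-dependent insulinotropic receptor (Rattus norvegicus), read by HTRF and cAMP accumulation; a lower number here means that less compound is needed, a higher number that more compound is needed for the effect. Compound 3 sits within the scatter of both neighbours: against compound 1 the gap is small, and the step of a 1.7-fold lower number from compound 2 to compound 3 (0.23 log units; within the scatter) is also within the scatter, so the numbers for these three compounds cannot be told apart.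

Compound 4 `CS(=O)(=O)c1cnc(O[C@H]2CC[C@H](OC3CCN(CC4(C(F)(F)F)CCCC4)CC3)CC2)cn1` has not yet been measured. It differs from compound 3 in one place: a group of 10 heavy atoms (7 carbon, 3 fluorine; one five-membered non-aromatic ring of carbon only) in place of a group of 6 heavy atoms (4 carbon, 2 oxygen; no ring), on an amine nitrogen in a ring. Among the measured compounds shown here, none of the measured steps touches this position. For the measured compounds named here, the only step on record, a 1.7-fold lower number from compound 2 to compound 3 (0.23 log units; within the scatter), concerns the aromatic ring and says nothing about the group on the amine nitrogen. Compound 1 and compound 2 carry different carbamates, but they also differ in the aromatic ring, so their values alone do not separate the two changes. There is thus no guide in the data for the size or direction of the step to compound 4, and the expectation must be wide. Compound 4 is expected to give roughly 250 nM, within a range from 50 nM to 1500 nM, which amounts to an expected step of a 2.1-fold higher number from compound 3 to compound 4 (0.32 log units; beyond the scatter).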

Compound 4, half-maximal effective concentration: 101 nM
Estimate against measurement, compound 4: 2.5-fold (0.39 log units) above, and the stated range covers the measured number.
By their numbers in this assay, from the lowest: compounds 4, 1, 3 and 2 (each within the scatter of the next).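

The step at this position is a 1.2-fold lower number from compound 3 to compound 4 (0.07 log units; within the scatter) in this assay, so the carbamate on the amine nitrogen can be exchanged for a very different group without a change that can be told apart from scatter. The isopropoxycarbonyl that leaves has 6 heavy atoms, 2 hydrogen-bond acceptors and no ring, whereas the group that enters has 10 heavy atoms, 0 hydrogen-bond acceptors and a five-membered carbon ring bearing three fluorines, so for this pair the carbamate carbonyl is not required for a number of this size. No measurement here explains why two such different groups give numbers that cannot be separated.

From the compounds shown here alone, it remains open whether the trifluoromethyl group contributes anything, which a plain cyclopentylmethyl or a cyclohexylmethyl group on the same nitrogen would help to show. Going by these compounds, it is also open how far this tolerance extends, for example to a free ring amine, a simple acetyl amide or a long straight alkyl chain, and whether the same exchange behaves alike on the methylsulfonylpyridine rings of compound 1 and compound 2.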